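A few compounds are considered here, and "the series" means these few. Any claim that something is new, unique, unknown or untested is made for them only; others in the source may bear on it.

Measured so far in a functional assay (strain AB) with Danio rerio as the target, read by microscopy, with a stated time of 1 h; a lower number here means that less compound is needed, a higher number that more compound is needed for the effect:
- compound 1, `CC(C)(C)OC(=O)CCCN1CCc2c(sc(NC(=O)Nc3ccc(Cl)cc3)c2C(N)=O)C1`: 560 nM
- compound 2, `CCN1CCc2c(sc(N)c2C(N)=O)C1`: > 25000 nM
- compound 3, `CC(C)(C)C[N+]1(C)CCc2c(sc(NC(=O)Nc3ccc(Cl)cc3)c2C(N)=O)C1`: 290 nM

Compound 2 yields only a limit in this assay, > 25000 nM, so no number is known for it; the limit of > 25000 nM in this assay, at which 1 of the 3 values shown sits, records this. Compound 1 gives 560 nM in this assay. Compound 3 gives 290 nM in this assay, the lower of the two numbers, yet its gap to compound 1 lies within the usual scatter of repeated measurements, so the two cannot be ranked against each other.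

Compound 4, `CC[N+]1(C)CCc2c(sc(NC(=O)Nc3ccc(Cl)cc3)c2C(N)=O)C1`, has not yet been measured in this assay. It is built from compound 3 by a single change: methyl in place of tert-butyl on a saturated chain carbon bound to an amine nitrogen in a ring. Among the compounds with values here, no measured pair of compounds differs by this change alone, so its effect cannot be read off directly. What is seen is that compound 1 and compound 3, which differ from each other in more than one place, sit within the scatter of each other. On that basis the step from compound 3 to compound 4 is expected to be small, in either direction, and not beyond the scatter: a 1.4-fold higher number from compound 3 to compound 4 (0.14 log units; within the scatter). For compound 4 the expected value in this assay is therefore 400 nM, with a range from 150 nM to 1200 nM.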

Compound 4, half-maximal effective concentration: 1960 nM
Estimate against measurement, compound 4: 4.9-fold (0.69 log units) below; measured number above the stated range.
By their numbers in this assay, from the lowest: compounds 3 and 1 (each within the scatter of the next); then compound 4. At a limit, above all of these: compound 2.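

Within the data shown here, compound 3 and compound 4 form the first pair here that differs in one place only, and in this assay putting methyl in place of tert-butyl gives a 6.8-fold higher number from compound 3 to compound 4 (0.83 log units; beyond the scatter) as a step that can be read directly. Among these compounds, this shows that the group on a saturated chain carbon bound to an amine nitrogen in a ring matters to the result, something the earlier compounds could not show, as none of them formed a single-change pair. Cut one bond further out, the same difference reads neopentyl to ethyl, so here the neopentyl compound has the lower number, although one pair cannot establish a trend.

The compounds shown leave open where a propyl or isobutyl group, a longer chain, or a chain ending in an amine or a carboxylic acid would fall in this assay and whether the number shifts gradually or abruptly from one group to the next. The reason for this step also stays open, as nothing measured here bears on it.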